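Fluoro to Nitro on a Shared Core

This account rests on a few compounds, and the source may have more. Where it says the series, first, only, none or still open, it means among the compounds named here.

Three compounds have been tested in an ADME assay on THP-1 cells (Homo sapiens) for cytotoxicity, read by MTT assay, tested at 50 ug/mL; on this read-out higher numbers stand for more inhibition at the one concentration tested (going by the name of the read-out) and lower numbers for less inhibition:

Compound 1, `Fc1ccc(-c2csc(N/N=C/c3ccc(-n4ccnc4)cc3)n2)cc1`: 18.7%
Compound 2, `Clc1ccc(-c2csc(N/N=C/c3ccc(-n4ccnc4)cc3)n2)c(Cl)c1`: 28.8%
Compound 3, `Fc1ccc(-c2csc(N/N=C/c3ccc(-n4cncn4)cc3)n2)cc1`: 35.9%

Compound 3 gives the highest of the three numbers, but compound 2 sits within the scatter of it, so the two cannot be ordered; only compound 1 lies clearly lower, by a number 17.2 percentage points higher from compound 1 to compound 3 (beyond the scatter).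

Compound 4, `O=[N+]([O-])c1ccc(-c2csc(N/N=C/c3ccc(-n4cncn4)cc3)n2)cc1`, is the next compound to go into this assay. It differs from compound 3 in one place: nitro in place of fluoro on an aromatic carbon. Among the measured compounds shown here, the one measured step that touches the same ring is the change of its substituent from compound 1 to compound 2, which gave a number 10.1 percentage points higher from compound 1 to compound 2 (beyond the scatter). For the measured compounds named here, that is the only guide, and it points to a modest rise or to no step beyond the scatter; nothing measured here argues for a drop.

Compound 4 is therefore expected to land a little above compound 3, with an estimated step of a number 6.1 percentage points higher from compound 3 to compound 4 (within the scatter). The estimate for compound 4 in this assay is 42%, within a range from 28% to 58%.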

Compound 4, a percentage reported as inhibition, at one concentration (the size of the read-out at that concentration, not a potency): 12.9%
Estimate against measurement, compound 4: 29.1 percentage points above; measured number outside the range, below it.
By their numbers in this assay, from the lowest: compounds 4 and 1 (each within the scatter of the next); then compounds 2 and 3 (each within the scatter of the next).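

In this assay the change from 4-fluorophenyl to 4-nitrophenyl gives a number 23 percentage points lower from compound 3 to compound 4 (beyond the scatter) and shows that a change on this ring can lower the number as well as raise it. The earlier step on this ring, a number 10.1 percentage points higher from compound 1 to compound 2 (beyond the scatter), went the other way, but it was a different change, 2,4-dichlorophenyl in place of 4-fluorophenyl, and its compounds carry 1H-imidazol-1-yl rather than 1H-1,2,4-triazol-1-yl, so the two steps together give no rule for this position. Nothing measured here offers a reason for the lower number with nitro in place of fluoro.

Among the compounds shown here, it remains open whether nitro in place of fluoro would also lower the number on the shared core when that core carries 1H-imidazol-1-yl, since this swap is seen only with 1H-1,2,4-triazol-1-yl. The compounds shown also leave open what other groups at this same place would do, such as an amine or a carboxylic acid, and whether the number would follow any trend across such a series.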